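The source may hold more compounds than are shown below. What is called first, only, known or untested is meant among the compounds shown, and "the series" means these compounds.

Compound 1, `COc1ccc([C@H]2CC(=O)N(c3cccc(O)c3)C2)cc1OC1CCCC1`, in a functional assay on HEK293 cells (Homo sapiens) for cytotoxicity (on this read-out higher numbers stand for lower toxicity in this test and lower numbers for higher toxicity in this test), gives > 10000 nM; this is a limit of the assay rather than a number. Compound 2, `COc1ccc([C@H]2CC(=O)N(c3cc(N)cc(N)c3)C2)cc1OC1CCCC1`, likewise gives only a limit, > 10000 nM. Among the measured compounds shown here, the single measured step, a step that the two limits leave unreadable from compound 1 to compound 2, is therefore unreadable in both size and direction, since the evidence amounts to the limit of > 10000 nM in this assay, at which 2 of the 2 values shown sit, and nothing more. Compound 3 is `COc1ccc([C@H]2CC(=O)N(c3cccc(NS(=O)(=O)c4cccc(Cl)c4C)c3)C2)cc1OC1CCCC1`. Relative to compound 1 the change is ((3-chloro-2-methylphenyl)sulfonyl)amino in place of hydroxy on an aromatic carbon. That unreadable step is the only measured one bearing on this position, and it supplies no size to carry over, so no direction beyond the scatter can be derived for compound 3; what the two measured values share is that both rest at the limit. Compound 3 is therefore expected to sit at about 20000 nM, in a range from 8000 nM to 60000 nM. This estimate corresponds to an expected step that the limit leaves unreadable from compound 1 to compound 3.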

Compound 3, half-maximal cytotoxic concentration: > 10000 nM
Compound 3: a limit, no number (the forecaster's own chance of this, stated with the estimate: 85%); the middle value is on the limit's open side.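

In this assay compound 3 gives > 10000 nM as a limit and not a number. The step from compound 1 to compound 3 therefore cannot be read in size or direction: the limit of > 10000 nM in this assay, at which 3 of the 3 values shown sit. The compounds shown leave open at what concentration any of them would reach half-maximal cytotoxicity.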